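The source may report more compounds than this note shows. Statements on the series, on what has been measured and on what is new or still open speak of the compounds shown alone.

In a toxicity assay on MDCK cells (Canis lupus familiaris) for cytotoxicity, read by crystal violet staining, with a stated time of 48 h (on this read-out lower numbers stand for higher toxicity in this test and higher numbers for lower toxicity in this test), compound 1 `Cc1ccc2[nH]c(=O)c(CN(Cc3ccc(F)cc3)Cc3ccc(C(C)(C)C)cc3)cc2c1` gives > 27000 nM, which is a limit and not a number. Compound 2 `CCc1ccc2[nH]c(=O)c(CN(Cc3ccc(F)cc3)Cc3ccc(C(C)(C)C)cc3)cc2c1` gives > 33000 nM, also a limit. Compound 3 `Cc1ccc2[nH]c(=O)c(CN(Cc3ccc(F)cc3)Cc3cccc4ccccc34)cc2c1` gives > 5000 nM, again a limit. Compound 4 `COc1ccc(CN(Cc2ccc(C(C)(C)C)cc2)Cc2cc3cc(C)ccc3[nH]c2=O)cc1` keeps the core of compound 1 and changes one group: methoxy in place of fluoro on an aromatic carbon. The measured changes elsewhere on the molecule are a step that the two limits leave unreadable from compound 1 to compound 2 and a step that the two limits leave unreadable from compound 1 to compound 3. Neither touches this group, and neither gives a readable size. The expectation is therefore no change beyond the scatter, an estimated at least 1.0-fold lower number from compound 1 to compound 4 (0.03 log units; that floor lies within the scatter). For compound 4 the expected value is 25000 nM, with an estimated range from 8000 nM to 60000 nM.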

Compound 4, half-maximal cytotoxic concentration: > 10000 nM
Compound 4: only a limit was reported; the forecaster's own chance of this, stated with the estimate: 75%; the middle value does not contradict the limit.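

Compound 1 and compound 4 each give only a limit, and the step between them cannot be read. The compounds shown leave open whether methoxy in place of fluoro changes the result in this assay at all.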